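The source may hold more compounds than are shown below. What is called first, only, known or untested is meant among the compounds shown, and "the series" means these compounds.

Compound 1, `O=C(NO)c1ccc(NCc2nc(-c3ccc(F)cc3)nn2-c2ccccc2)cc1`, is the reference point of this account. In an assay on Sf9 cells for inhibition of protein deacetylase HDAC6 (Homo sapiens), read by fluorescence, with a stated time of 40 min, tested at 100 nM (a lower number here means less inhibition, a higher number more inhibition at the concentration tested (going by the name of the read-out)), compound 1 gives 70.9%, the highest of the three numbers measured; compound 3, `O=C(NO)c1ccc(NCc2nc(-c3ccccc3)nn2-c2ccc(F)cc2)cc1`, gives 67.6%, which lies within the scatter of compound 1, while compound 2, `Cc1ccc(-n2nc(-c3ccccc3)nc2CNc2ccc(C(=O)NO)cc2)cc1C`, gives 53%, a number beyond the scatter below compound 1.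

For the measured compounds named here, the one step measured between compounds that differ in a single place is the replacement of 3,4-dimethylphenyl by 4-fluorophenyl on an aromatic nitrogen, a number 14.6 percentage points higher from compound 2 to compound 3 (beyond the scatter). Compound 4, `O=C(NO)c1ccc(NCc2nc(-c3cccc4cnccc34)nn2-c2ccccc2)cc1`, differs from compound 1 elsewhere: isoquinolin-5-yl in place of 4-fluorophenyl on an aromatic carbon. Going by the values given here, no measured step touches that aromatic carbon, so the one available step only shows that a change of the substituent on the neighbouring aromatic nitrogen moved this assay by a modest amount. Compounds 1 and 3, which carry the fluorine on different rings, give values within the scatter of each other.

With nothing measured at the changed position, the account expects no step beyond the scatter, with the estimate leaning slightly downward for the larger isoquinolin-5-yl group, a number 5.9 percentage points lower from compound 1 to compound 4 (within the scatter). For compound 4 in this assay the estimated value is 65%, within a range from 45% to 85%.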

Compound 4, a percentage reported as inhibition, at one concentration (the size of the read-out at that concentration, not a potency): 40.2%
Beside the measured number, compound 4's estimate is 24.8 percentage points above it, and the stated range ends above it.
By their numbers in this assay, from the lowest: compound 4; then compound 2; then compounds 3 and 1 (each within the scatter of the next).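

For the compounds shown here, at the aromatic carbon between two ring nitrogen atoms, the number in this assay turns out lower: isoquinolin-5-yl in place of 4-fluorophenyl gives a number 30.7 percentage points lower from compound 1 to compound 4 (beyond the scatter), a large step, whereas the only earlier step, on the aromatic nitrogen, was modest at a number 14.6 percentage points higher from compound 2 to compound 3 (beyond the scatter). The exchange adds a six-membered aromatic ring with 1 hetero atom to the ring of carbon only, and brings 1 hydrogen-bond acceptor where the leaving group has none, so several features change together in this one step and it cannot assign the loss to any one of them. Nothing available speaks to the reason for this loss.

The compounds shown leave open whether the loss follows the fused ring or its ring nitrogen, a question that a naphthalen-1-yl group, with carbon only, and a pyridin-3-yl group on this same aromatic carbon could separate. They also leave open whether a plain phenyl group here would stay level with compound 1 70.9%, which would show how much the fluorine contributes at this place.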